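The compounds below may be only part of what the source reports. "The series", "measured", "known", "first", "only" and "open" are said of these compounds alone.

Measured so far:
- compound 1 `CC(C)n1cnc2c(NCc3ccc(C(=O)Nc4ccccc4N)cc3)nc(Cl)nc21`: 73.2%
- compound 2 `Nc1ccccc1NC(=O)c1ccc(CNc2nc(Cl)nc3c2ncn3Cc2ccccc2)cc1`: 7.7%

In a functional assay on HCT-116 cells (Homo sapiens) for antiproliferative activity, read by CCK-8 assay, with a stated time of 72 h, tested at 2 uM (a higher number here means a stronger effect of the compound at the concentration tested, a lower number a weaker effect), compound 2 gives the lower of the two numbers, and its nearest neighbour, compound 1, lies well beyond the scatter above it. Compound 3 `CCCn1cnc2c(NCc3ccc(C(=O)Nc4ccccc4N)cc3)nc(Cl)nc21` is the next compound to be measured. It differs from compound 2 by ethyl in place of phenyl on a saturated chain carbon bound to an aromatic nitrogen; seen one bond further out, this reads as benzyl to propyl. Among the compounds with values here, the one measured step that bears on this change is the step from compound 1 to compound 2, in which a benzyl replaced an isopropyl on an aromatic nitrogen and a number 65.5 percentage points lower from compound 1 to compound 2 (beyond the scatter). Since compound 3 carries a propyl, a short chain that resembles the isopropyl of compound 1 rather than the benzyl of compound 2, a large rise is expected in this assay, of about a number 52.3 percentage points higher from compound 2 to compound 3 (beyond the scatter). Compound 3 is therefore estimated to give 60%, with a range from 30% to 82%.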

Compound 3, a percentage reported as inhibition, at one concentration (the size of the read-out at that concentration, not a potency): 28.5%
Beside the measured number, compound 3's estimate is 31.5 percentage points above it, and the stated range ends above it.
By their numbers in this assay, from the lowest: compound 2; then compound 3; then compound 1.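

In this assay, swapping the phenyl of the benzyl for ethyl, which turns benzyl into propyl on the aromatic nitrogen, gives a number 20.8 percentage points higher from compound 2 to compound 3 (beyond the scatter). Changing the branched isopropyl to the straight propyl gives a number 44.7 percentage points lower from compound 1 to compound 3 (beyond the scatter). A short chain on this nitrogen therefore does not by itself bring back the number seen with isopropyl: among these three compounds the position responds to the shape of the chain, not only to the loss of the phenyl.

Nothing available here explains the gap between isopropyl and propyl. As far as these compounds go, it remains open whether a cyclopropyl, a tert-butyl or a longer chain such as butyl on the same nitrogen would fall nearer compound 1 or nearer compound 3.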